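The compounds below may be only part of what the source reports. "The series", "measured", "known", "first", "only" and "open" are said of these compounds alone.

Two indole-based compounds share a core in which a pyridine-bearing ketone arm sits on the five-membered ring. Compound 1 `COc1ccc2[nH]c(C(=O)Cc3cccnc3)cc2c1` carries a methoxy group on its six-membered carbon ring; in an in vitro assay on P815B cells for inhibition of Indoleamine 2,3-dioxygenase 1 (Mus musculus), tested at 20 uM (a higher number here means more inhibition at the concentration tested (going by the name of the read-out), a lower number less inhibition), compound 1 has "not determined" (no result reported), so no single number places it on the scale. Compound 2 `COc1ccc2[nH]c(C(=O)Cc3cccnc3)cc2c1O` adds a hydroxyl to the same ring, and in this assay compound 2 gives 11%, a weak response. Compound 3 `O=C(Cc1cccnc1)c1cc2cc(Cl)ccc2[nH]1` has not yet been measured; it differs from compound 1 by chloro in place of methoxy on an aromatic carbon. For the measured compounds named here, no measured pair shows the effect of that change, and compound 1 itself has no value, so the step from compound 1 to compound 3 in this assay cannot be sized from data; the only anchor, compound 2 at 11%, suggests the series sits low, and a change of no more than the usual scatter is expected. Compound 3 is therefore estimated at 15%, with a likely range from 0% to 40%.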

Compound 3, a percentage reported as inhibition, at one concentration (the size of the read-out at that concentration, not a potency): 24%
Beside the measured number, compound 3's estimate is 9 percentage points below it; the measured number falls inside the stated range.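

For the compounds shown here, compound 1 has no single number in this assay, so no step from compound 1 to compound 3 can be read. Going by these compounds, what swapping methoxy for chloro does to inhibition stays open. Nothing here offers an explanation for the result of compound 3.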